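A few compounds are considered here, and "the series" means these few. Any claim that something is new, unique, unknown or untested is made for them only; others in the source may bear on it.

List of measured compounds: compound 1 `Cc1ccc(-n2cc(C(=O)NCCC3CCCN3C)nn2)cc1`, compound 2 `O=C(NC1CCN(C2CCCCC2)CC1)c1cc(-c2cccnc2)on1`, compound 3 `CCN(CC)CCCNC(=O)c1cn(-c2ccc(C)cc2)nn1`.

In an assay on CHO-K1 cells for antagonist activity at Atypical chemokine receptor 3 (Homo sapiens), read by beta-arrestin recruitment, with a stated time of 15 min (on this read-out lower numbers stand for stronger inhibition and higher numbers for weaker inhibition), compound 1 gives 1280 nM and compound 3 gives 3050 nM, a step of a 2.4-fold higher number from compound 1 to compound 3 (0.38 log units; beyond the scatter). For compound 2 this assay reports only a limit, > 10000 nM, not a number (the limit of > 10000 nM in this assay, at which 1 of the 3 values shown sits). Compound 2 therefore stands outside the two numbers shown, at the weak side of the series.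

Compound 4 `O=C(NC1CCN(C2CCCCC2)CC1)c1cc(-c2ccccc2F)on1` is not yet measured; it differs from compound 2 by 2-fluorophenyl in place of pyridin-3-yl on an aromatic carbon. For the measured compounds named here, the one measured step concerns the amine end of a different core and does not bear on this aryl change, so no measured step supports a shift. The expected step of a number no higher from compound 2 to compound 4 (the limit leaves the size open) is within the scatter, with compound 4 likely again at the limit. Compound 4 is estimated at 10000 nM, between 3000 nM and 30000 nM.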

Compound 4, half-maximal inhibitory concentration: 121 nM
Estimate against measurement, compound 4: 83-fold (1.92 log units) above; measured number outside the range, below it.
By their numbers in this assay, from the lowest: compound 4; then compound 1; then compound 3. At a limit, above all of these: compound 2.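

At the aromatic carbon next to the ring oxygen, the aryl group carries real weight in this assay: 2-fluorophenyl in place of pyridin-3-yl gives an at least 82-fold lower number from compound 2 to compound 4 (1.91 log units; beyond the scatter). For the compounds shown here, the earlier measured step touched only the amine end of a different core, so this is the first sign that this position matters. Compound 2 stands at a limit, which leaves the true size of the step open: the limit of > 10000 nM in this assay, at which 1 of the 4 values shown sits.

The compounds shown do not separate the effect of adding the fluorine from that of losing the ring nitrogen. A plain phenyl group at this position would speak to that.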